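A few compounds are considered here, and "the series" means these few. Any claim that something is new, unique, unknown or untested is made for them only; others in the source may bear on it.

Working notes on the series.

Compound 2 `O=C(N/N=C/c1cccc(Cl)c1)c1cccnc1Nc1cccc(C(F)(F)F)c1` stands highest of the three numbers in a functional assay on the whole organism (strain Wistar) for inhibition, with Rattus norvegicus as the target, read by paw edema, with a stated time of 30 min, at a dose of 10 mg/kg by the intraperitoneal route (a higher number here means more inhibition at the dose given (going by the name of the read-out), a lower number less inhibition), with 77.8%; compound 3 `O=C(N/N=C/c1cccc(O)c1)c1cccnc1Nc1cccc(C(F)(F)F)c1` gives 67.5% and compound 1 `O=C(N/N=C/c1ccccc1)c1cccnc1Nc1cccc(C(F)(F)F)c1` gives 60.4%. Compound 4 `COc1cccc(/C=N/NC(=O)c2cccnc2Nc2cccc(C(F)(F)F)c2)c1` differs from compound 2 by methoxy in place of chloro on an aromatic carbon. Among the compounds with values here, two measured steps bear on this: a number 17.4 percentage points higher from compound 1 to compound 2 (beyond the scatter) and a number 10.3 percentage points lower from compound 2 to compound 3 (beyond the scatter), the second being the closest analogue, as hydroxy and methoxy both put an oxygen where the chloro stood. The step of a number 7.1 percentage points higher from compound 1 to compound 3 (within the scatter) suggests an oxygen substituent sits near the unsubstituted parent. A modest drop from compound 2 is therefore expected, estimated at a number 8.8 percentage points lower from compound 2 to compound 4 (within the scatter). Compound 4 is expected to give about 69% in this assay, in the range 57% to 81%.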

Compound 4, a percentage reported as inhibition, in the whole organism at one dose (the size of the read-out at that dose, not a potency): 52.8%
For compound 4 the middle estimate is 16.2 percentage points above the measured one; measured number outside the range, below it.
By their numbers in this assay, from the lowest: compounds 4, 1 and 3 (each within the scatter of the next, the first and the last beyond it); then compound 2.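

In this assay the two oxygen substituents at this place part: methyl in place of hydrogen on the oxygen gives a number 14.7 percentage points lower from compound 3 to compound 4 (beyond the scatter), a change the hydroxy compound alone could not reveal. Methoxy also falls clearly short of chloro, with a number 25 percentage points lower from compound 2 to compound 4 (beyond the scatter), yet stays level with the unsubstituted parent, with a number 7.6 percentage points lower from compound 1 to compound 4 (within the scatter), so of the substituents shown only chloro stands beyond the scatter of that parent. Nothing at hand accounts for these steps. From the compounds shown here alone, whether an amine, a nitrile or a longer ethoxy chain at this place would track chloro or methoxy remains open.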